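This account rests on a few compounds, and the source may have more. Where it says the series, first, only, none or still open, it means among the compounds named here.

Measured so far in an ADME assay on HepG2 cells (Homo sapiens) for cytotoxicity, read by MTT assay, with a stated time of 24 h; a higher number here means that more compound is tolerated, a lower number that less compound is tolerated:
compound 1, `OCCCc1cn(-c2ccnc3cc(Cl)ccc23)nn1`: compound 1 gives 151000 nM.
compound 2, `O=C(OCCCc1cn(-c2ccnc3cc(Cl)ccc23)nn1)c1ccccc1`: compound 2 gives 1200000 nM.
compound 3, `O=C(OCCCc1cn(-c2ccnc3cc(Cl)ccc23)nn1)c1ccc(C(F)(F)F)cc1`: compound 3 gives only a limit, > 2170000 nM.

Compound 3 therefore sits at the ceiling of this assay, (the limit of > 2170000 nM in this assay, at which 1 of the 3 values shown sits), with no number of its own. Compound 4, `Cc1ccc(C(=O)OCCCc2cn(-c3ccnc4cc(Cl)ccc34)nn2)cc1`, differs from it by methyl in place of trifluoromethyl on an aromatic carbon. For the measured compounds named here, two measured steps bear on this. a 7.9-fold higher number from compound 1 to compound 2 (0.90 log units; beyond the scatter) was the only step beyond the scatter; an at least 1.8-fold higher number from compound 2 to compound 3 (0.25 log units; that floor lies within the scatter), the step that put the trifluoromethyl in, stayed within it. Swapping that trifluoromethyl for a methyl is therefore expected to move the number no further than the scatter, and the direction is open. Compound 4 is expected at 2000000 nM (range 900000 nM to 4500000 nM), that is an at least 1.0-fold lower number from compound 3 to compound 4 (0.03 log units; that floor lies within the scatter).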

Compound 4, half-maximal cytotoxic concentration: > 2460000 nM
Compound 4 was reported as a limit; the forecaster's own chance of this, stated with the estimate: 40%; at least 1.2-fold (0.08 log units) between middle value and limit.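

In this assay compound 4, like compound 3, returns only a limit, not a number: the limit of > 2460000 nM in this assay, at which 1 of the 4 values shown sits.
Methyl on this aromatic carbon gives an at least 2.0-fold higher number from compound 2 to compound 4 (0.31 log units; beyond the scatter), a floor beyond the scatter, which the trifluoromethyl floor did not reach, and the whole 4-methylphenyl carbonyl group gives an at least 16-fold higher number from compound 1 to compound 4 (1.21 log units; beyond the scatter). The step between methyl and trifluoromethyl cannot be read, as both values are limits.

Still open, as far as these compounds go, is whether an amine or a carboxylic acid on this aromatic carbon would bring the number back below the limits. An amide in place of the ester is equally untested here.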